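Methoxy in Place of Diethylamino on a Hydrazone Scaffold

A few compounds are considered here, and "the series" means these few. Any claim that something is new, unique, unknown or untested is made for them only; others in the source may bear on it.

Compound 1 `O=C(N/N=C/c1ccco1)c1cccc(S(=O)(=O)N2CCOCC2)c1`: in a functional assay on PC-3 cells (Homo sapiens) for antiproliferative activity, read by MTT assay, with a stated time of 72 h (on this read-out higher numbers stand for weaker inhibition and lower numbers for stronger inhibition), compound 1 gives > 100000 nM, which is a limit of the assay and not a number.
Compound 2 `CCN(CC)c1ccc(/C=N/NC(=O)c2cccc(S(=O)(=O)N3CCOCC3)c2)c(O)c1`: in this assay compound 2 gives 14000 nM.

Compound 2 therefore holds the only number shown in this assay. The other value shown belongs to compound 1 and is only a limit, as one of the two values sits at the limit of > 100000 nM in this assay, at which 1 of the 2 values shown sits. For the measured compounds named here, no pair of measured compounds differs in a single place, so no measured step is available to calibrate what a small change on the aromatic ring does here.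

Compound 3 `COc1ccc(/C=N/NC(=O)c2cccc(S(=O)(=O)N3CCOCC3)c2)c(O)c1` has not yet been measured. It differs from compound 2 by methoxy in place of diethylamino on an aromatic carbon. Going by the values given here, with no measured step to lean on, the expected step from compound 2 is modest and leans toward weaker inhibition, and is estimated as a 2.1-fold higher number from compound 2 to compound 3 (0.33 log units; beyond the scatter). For compound 3 the expected value in this assay is 30000 nM, with a range from 8000 nM to 100000 nM; a result reported only as a limit would not be surprising.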

Compound 3, half-maximal inhibitory concentration: 5800 nM
Compound 3: middle estimate off by 5.2-fold (0.71 log units), on the high side; measured number outside the range, below it.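

In this assay, the aromatic carbon meta to a hydroxy group and para to a large group tolerates losing diethylamino: methoxy in its place gives a 2.4-fold lower number from compound 2 to compound 3 (0.38 log units; beyond the scatter). The basic activity of this series at that position therefore does not depend on diethylamino, and among these two groups the smaller methoxy, with 2 heavy atoms against 5, goes with the lower number. The change of the whole aryl part, 2-hydroxy-4-methoxyphenyl in place of furan-2-yl, gives an at least 17-fold lower number from compound 1 to compound 3 (1.23 log units; beyond the scatter), yet compound 1 stands at a limit and not a number, so this step fixes only a minimum size: the limit of > 100000 nM in this assay, at which 1 of the 3 values shown sits.

What the compounds shown leave open is whether the lower number belongs to methoxy itself, or whether ethoxy, dimethylamino, a plain hydrogen or a hydroxy group on the same carbon would read the same in this assay. They also leave open how much of the step from the furan-2-yl compound comes from the hydroxy group and how much from the methoxy group, since both enter together.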